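The source may hold more compounds than are shown below. What is called first, only, known or untested is meant among the compounds shown, and "the series" means these compounds.

Measured compounds:
compound 1 `Cc1cc(O)c(C2=NN(c3ccc(S(N)(=O)=O)cc3)C(c3ccccc3O)C2)cc1Cl`: > 100000 nM
compound 2 `Cc1cc(O)c(C2=NN(c3ccc(S(N)(=O)=O)cc3)C(c3ccccc3Cl)C2)cc1Cl`: > 100000 nM

In a functional assay on RPMI-8226 cells (Homo sapiens) for antiproliferative activity, with a stated time of 48 h (on this read-out higher numbers stand for lower toxicity in this test and lower numbers for higher toxicity in this test), compound 1 gives > 100000 nM, a limit of the test rather than a number. In this assay compound 2 gives > 100000 nM, likewise only a limit. Among the compounds with values here, the one measured step, a step that the two limits leave unreadable from compound 1 to compound 2, therefore cannot be read, since both of its ends sit at the limit of > 100000 nM in this assay, at which 2 of the 2 values shown sit. Compound 2 thus stands at the limit, with no number to place it against.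

Compound 3 `Cc1cc(O)c(C2=NN(c3ccc(S(N)(=O)=O)cc3)C(/C=C/c3ccccc3)C2)cc1Cl` arises from compound 2 by 2-phenylethenyl in place of 2-chlorophenyl on a saturated ring carbon. Within the data shown here, no measured step speaks to this change, and the only step available is unreadable, so nothing points to a move in either direction beyond the scatter. The step expected from compound 2 to compound 3 is therefore a number no higher from compound 2 to compound 3 (the limit leaves the size open). Compound 3 is expected to give 100000 nM, within a range from 30000 nM to 300000 nM, most likely reported again as a limit.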

Compound 3, concentration lethal to 50% of the cells: 575 nM
Compound 3: middle estimate off by 170-fold (2.24 log units), on the high side; measured number outside the range, below it.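

The group on this saturated ring carbon decides whether this assay gives a number at all: 2-phenylethenyl in place of 2-chlorophenyl gives an at least 170-fold lower number from compound 2 to compound 3 (2.24 log units; beyond the scatter), and in place of 2-hydroxyphenyl it gives an at least 170-fold lower number from compound 1 to compound 3 (2.24 log units; beyond the scatter). Compound 1 and compound 2 stay at a limit of the test, not at a number: the limit of > 100000 nM in this assay, at which 2 of the 3 values shown sit. Their shared limit hid this sensitivity, whereas compound 3 now shows that a change at this one place can bring a large move in toxicity in this test.

From the compounds shown here alone, whether the double bond outside the aromatic ring is what counts stays open, and a saturated 2-phenylethyl group would speak to that. Going by these compounds, it is also open whether an amine or a carboxylic acid on the phenyl ring of the 2-phenylethenyl group would keep a number of this size.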